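Swapping Fluoro for Chloro on a Kinase Inhibitor

This account rests on a few compounds, and the source may have more. Where it says the series, first, only, none or still open, it means among the compounds named here.

Compound 1 `COc1ccc2c(c1)CC(C(=O)Nc1ccc(-c3cn[nH]c3)c(OC)c1)CO2` and compound 2 `COc1cc(-c2cn[nH]c2)ccc1NC(=O)C1COc2ccc(F)cc2C1` share the same core and differ only in how their small substituents are arranged. In an assay on isolated protein for inhibition of Rho-associated protein kinase 2 (Homo sapiens) (on this read-out lower numbers stand for stronger inhibition and higher numbers for weaker inhibition), compound 1 gives 3 nM. In this assay compound 2 gives 3 nM, level with compound 1 at the digits shown; the two values lie within the usual scatter of each other, so no order between them can be drawn.

Compound 3 `COc1cc(-c2cn[nH]c2)ccc1NC(=O)C1COc2ccc(Cl)cc2C1` is built from compound 2 by a single exchange: chloro in place of fluoro on an aromatic carbon of the fused ring. Within the data shown here, no measured pair in this set shows what this exchange does, so its size cannot be read off from data. The exchange, as counted, brings no ring and no hydrogen-bond donor or acceptor, and one halogen replaces another. The expected step of no change at the digits printed from compound 2 to compound 3 (within the scatter) is therefore small, no larger than the scatter, with no clear direction. Compound 3 is expected to give about 3 nM in this assay, with a likely range from 1 nM to 10 nM.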

Compound 3, half-maximal inhibitory concentration: 3 nM
Estimate against measurement, compound 3: no gap at the digits printed; measured number inside the range.
By their numbers in this assay, from the lowest: compounds 1, 2 and 3 (each within the scatter of the next).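

In this assay, among these compounds, this is the first measured pair that isolates one halogen exchange on the aromatic carbon of the fused ring, and chloro in place of fluoro gives no change at the digits printed from compound 2 to compound 3 (within the scatter) in a single step. Fluoro and chloro each count as one heavy atom with no ring, no hydrogen-bond donor or acceptor and no net charge, so at this position the larger halogen atom can stand in for the smaller one with the read-out staying level at the digits shown, a finding that rests on this one pair alone. The data offer no measurement that bears on why these two halogens read alike.

As far as these compounds go, what remains open is whether this position responds to anything other than a halogen, since all the values shown sit level and none reveals a substituent there that moves the number. A basic amine, a carboxylic acid or a longer chain such as a propyl group on the same aromatic carbon would test how much room for change this position really has.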